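Aryl thioureas on a shared core: the methoxyphenyl step

The compounds below may be only part of what the source reports. "The series", "measured", "known", "first", "only" and "open" are said of these compounds alone.

Measured so far in a functional assay on U-373MG ATCC cells (Homo sapiens) for inhibition, read by MTT assay, with a stated time of 72 h; a higher number here means a weaker inhibitor, a lower number a stronger inhibitor:
compound 1 `CC1(C)CC(NC(=S)Nc2cccc(Cl)c2)c2cc(Br)ccc2O1` gives 8000 nM;
compound 2 `CC1(C)CC(NC(=S)Nc2cccc([N+](=O)[O-])c2)c2cc(Br)ccc2O1` gives 4000 nM;
compound 3 `CC1(C)CC(NC(=S)Nc2ccccc2)c2cc(Cl)ccc2O1` gives 46000 nM.

Compound 1 stands second highest of the three numbers. Its nearest neighbour is compound 2, with a 2.0-fold lower number from compound 1 to compound 2 (0.30 log units; within the scatter). Compound 3 lies furthest from it, its number beyond the scatter on the high side.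

Compound 4 `COc1ccc(NC(=S)NC2CC(C)(C)Oc3ccc(Br)cc32)cc1` is not yet measured. It differs from compound 1 as follows: 4-methoxyphenyl in place of 3-chlorophenyl on an amide-type nitrogen. Going by the values given here, the only measured step on the aryl group, a 2.0-fold lower number from compound 1 to compound 2 (0.30 log units; within the scatter), stays within the scatter; no step covers an aryl change of this kind on the amide-type nitrogen. A step in this assay of no change at the digits printed from compound 1 to compound 4 (within the scatter) is therefore expected, with neither direction favoured. For compound 4 the estimate is 8000 nM, between 2500 nM and 25000 nM.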

Compound 4, half-maximal inhibitory concentration: 40000 nM
Compound 4: the middle estimate sits 5.0-fold (0.70 log units) below what was measured, outside the stated range (above it).
By their numbers in this assay, from the lowest: compounds 2 and 1 (each within the scatter of the next); then compounds 4 and 3 (each within the scatter of the next).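

In this assay the aryl group on the amide-type nitrogen can move the number: the step is a 5.0-fold higher number from compound 1 to compound 4 (0.70 log units; beyond the scatter) while the earlier step on this group, a 2.0-fold lower number from compound 1 to compound 2 (0.30 log units; within the scatter), gave no separation. The change from 3-chlorophenyl to 4-methoxyphenyl alters both the substituent and its ring position, so the step cannot be assigned to either alone. No evidence on the cause of this step is at hand.

The compounds shown leave open whether 3-methoxyphenyl or 4-chlorophenyl on the shared core would track compound 1 or compound 4. They also leave open how a carboxylic acid or an amine on this aryl ring would read.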